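The source may hold more compounds than are shown below. What is called first, only, known or untested is meant among the compounds shown, and "the series" means these compounds.

Compound 1 `Oc1cccc(-c2cc(-c3ccccc3O)nc(-c3ccccc3O)c2)c1` gives 3420 nM in a functional assay on T47D cells (Homo sapiens) for cytotoxicity, read by CCK-8 assay, with a stated time of 4 days; a lower number here means a stronger inhibitor, a higher number a weaker inhibitor. Compound 2 `Oc1cccc(-c2cc(-c3cccc(O)c3)nc(-c3ccccc3O)c2)c1`, which differs by 3-hydroxyphenyl in place of 2-hydroxyphenyl on an aromatic carbon, gives 50000 nM; the step of a 15-fold higher number from compound 1 to compound 2 (1.16 log units; beyond the scatter). Compound 3 `Oc1ccc(-c2cc(-c3ccccc3O)nc(-c3ccccc3O)c2)cc1` differs from compound 1 by 4-hydroxyphenyl in place of 3-hydroxyphenyl on an aromatic carbon. Compound 3 gives 18300 nM, so that a 5.4-fold higher number from compound 1 to compound 3 (0.73 log units; beyond the scatter).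

Compound 4 `Oc1ccc(-c2cc(-c3cccc(O)c3)nc(-c3ccccc3O)c2)cc1` is not yet measured. It differs from compound 3 by 3-hydroxyphenyl in place of 2-hydroxyphenyl on an aromatic carbon. This is the same kind of change as that from compound 1 to compound 2, though the surroundings differ: the earlier change sat meta to a 2-hydroxyphenyl group and meta to a 3-hydroxyphenyl group, the new one sits meta to a 2-hydroxyphenyl group and meta to a 4-hydroxyphenyl group. Because a 15-fold higher number from compound 1 to compound 2 (1.16 log units; beyond the scatter) was large, compound 4 is expected to be weaker than compound 3, with an estimated 2.7-fold higher number from compound 3 to compound 4 (0.44 log units; beyond the scatter). Compound 4 is therefore estimated at 50000 nM, between 20000 nM and 150000 nM.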

Compound 4, half-maximal inhibitory concentration: 4810 nM
Compound 4: middle estimate off by 10-fold (1.02 log units), on the high side, and the stated range ends above it.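

The new step is a 3.8-fold lower number from compound 3 to compound 4 (0.58 log units; beyond the scatter), whereas the same change raised the number on the earlier core, so in this assay putting 3-hydroxyphenyl in place of 2-hydroxyphenyl did not carry over from one core to the other: the same change on two cores in this assay, a 15-fold higher number (1.16 log units; beyond the scatter) from compound 1 to compound 2 and a 3.8-fold lower number (0.58 log units; beyond the scatter) from compound 3 to compound 4, 56-fold (1.75 log units) apart, beyond the scatter of two such steps. Putting 4-hydroxyphenyl in place of 3-hydroxyphenyl also behaved differently on the two cores, with a 10-fold lower number from compound 2 to compound 4 (1.02 log units; beyond the scatter): the same change on two cores in this assay, a 5.4-fold higher number (0.73 log units; beyond the scatter) from compound 1 to compound 3 and a 10-fold lower number (1.02 log units; beyond the scatter) from compound 2 to compound 4, 56-fold (1.75 log units) apart, beyond the scatter of two such steps. The effect of each change therefore depends on the other groups present, but these four compounds do not show why, or how any other core would respond.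

On these data alone, it remains open whether an amine or a carboxylic acid in place of a hydroxyl group would show the same dependence on the core.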